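Adding a methyl to the chain of compound 2

The compounds below may be only part of what the source reports. "The series", "measured", "known", "first", "only" and "open" are said of these compounds alone.

Compound 1 `COC(=O)c1c[nH]c2cc(OCCOc3ccccc3)c(C)cc2c1=O`: > 20000 nM
Compound 2 `CCCCc1cc2c(=O)c(C(=O)OC)c[nH]c2cc1OCCOc1ccccc1`: > 20000 nM

In an ADME assay on J774 cells (Mus musculus) for cytotoxicity (on this read-out lower numbers stand for an effect already at smaller amounts and higher numbers for an effect only at larger amounts of compound), compound 2 gives > 20000 nM and this is a limit of the assay, not a number. Compound 1 gives > 20000 nM and this too is a limit, not a number. Neither compound therefore has an exact position on the scale, and the two share one reading, (the limit of > 20000 nM in this assay, at which 2 of the 2 values shown sit).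

The next compound, compound 3 `CCCCCc1cc2c(=O)c(C(=O)OC)c[nH]c2cc1OCCOc1ccccc1`, differs from compound 2 by one small change at the end of the chain: methyl in place of hydrogen on a saturated chain carbon, four bonds along the chain from an aromatic carbon. In words, this is methyl in place of hydrogen on a saturated chain carbon, four bonds along the chain from an aromatic carbon.

Going by the values given here, only one measured step bears on this change, a step that the two limits leave unreadable from compound 1 to compound 2. It offers no size to carry forward, so no step beyond the usual scatter is expected, and no direction can be named. The expected step is a number no higher from compound 2 to compound 3 (the limit leaves the size open). For compound 3 the estimated value in this assay is 20000 nM, with an expected range from 12000 nM to 40000 nM.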

Compound 3, half-maximal effective concentration: > 20000 nM
Compound 3 gave a limit, no number; the forecaster's own chance of this, stated with the estimate: 80%; the middle value sits exactly at the limit.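

Going by these compounds alone, compound 1, compound 2 and compound 3 all stop at the same limit of the assay in this assay, not at a number, so no step between them can be read. As far as these compounds go, what stays open is whether lengthening the chain on the shared core changes the effect on these cells at all, and at what concentration each compound would begin to show one.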